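Isopropyl in place of dimethylamino on the aryl ring

This account rests on a few compounds, and the source may have more. Where it says the series, first, only, none or still open, it means among the compounds named here.

Compound 1, `CCN(c1nc(C)cc(C)n1)c1c(Br)cc(OC)cc1OC`, gives 12 nM in an assay on isolated protein for binding affinity to corticotropin-releasing factor receptor 1 (Homo sapiens); a higher number here means a weaker inhibitor, a lower number a stronger inhibitor. Compound 2, `CCN(c1nc(C)cc(C)n1)c1c(Br)cc(N(C)C)cc1OC`, gives 5 nM in this assay, and the change a 2.4-fold lower number from compound 1 to compound 2 (0.38 log units; beyond the scatter) is modest. Compound 3, `CCN(c1ccc(C(C)C)cc1)c1nc(C)cc(C)n1`, returns only a limit, > 1000 nM, in this assay. Among the two plain numbers compound 2 holds the lower one, with compound 1 the nearest to it.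

Compound 4, `CCN(c1nc(C)cc(C)n1)c1c(Br)cc(C(C)C)cc1OC`, differs from compound 2 by isopropyl in place of dimethylamino on an aromatic carbon. Among the measured compounds shown here, the only measured step at this same position is the one from compound 1 to compound 2, which was modest; no measured step swaps an amine for an alkyl group on this ring, and the limit of compound 3 sits on a different aryl ring. The expectation therefore is a step of no more than modest size in this assay, if anything toward a somewhat higher number. For compound 4 the estimated value in this assay is 10 nM, within 3 nM to 40 nM, which means an expected step of a 2.0-fold higher number from compound 2 to compound 4 (0.30 log units; within the scatter).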

Compound 4, inhibition constant: 26 nM
Estimate against measurement, compound 4: 2.6-fold (0.41 log units) below; measured number inside the range.
By their numbers in this assay, from the lowest: compound 2; then compound 1; then compound 4. At a limit, above all of these: compound 3.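

Isopropyl in place of dimethylamino gives a 5.2-fold higher number from compound 2 to compound 4 (0.72 log units; beyond the scatter), and isopropyl in place of methoxy gives a 2.2-fold higher number from compound 1 to compound 4 (0.34 log units; beyond the scatter). Among the compounds shown here, the three groups at this position, para to a large group, therefore now fall into one order in this assay, with dimethylamino giving the lowest number, methoxy the next and isopropyl the highest, whereas the earlier compounds compared only dimethylamino and methoxy. Even with an all-carbon group here, compound 4 still gives 26 nM, and nothing shown accounts for this order.

The compounds shown leave open how a primary amine, a hydroxyl group or a longer chain such as n-butyl would fall within this order. For the compounds shown here, they also leave open whether the same order would hold on a core other than the one shared by compound 1, compound 2 and compound 4.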